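Replacing a Bromophenyl with a Hydroxyphenyl on Compound 1

The source may hold more compounds than are shown below. What is called first, only, known or untested is meant among the compounds shown, and "the series" means these compounds.

Measured so far in an ADME assay on HFF cells (Homo sapiens) for cytotoxicity, read by MTT assay, with a stated time of 72 h; on this read-out lower numbers stand for stronger inhibition and higher numbers for weaker inhibition:
Compound 1 `O=C1O/C(=C\Cn2cc(-c3ccc(Br)cc3)nn2)C(OCc2ccccc2)=C1OCc1ccccc1` gives > 100000 nM, which is a limit of this assay and not a number.
Compound 2 `CC(C)(C)OC(=O)N1CCN(C(=S)SCc2cn(C[C@H](O)[C@H]3OC(=O)C(OCc4ccccc4)=C3OCc3ccccc3)nn2)CC1` gives 60 nM.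
Compound 3 `O=C1O/C(=C\Cn2cc(-c3cc(C(F)(F)F)cc(C(F)(F)F)c3)nn2)C(OCc2ccccc2)=C1OCc1ccccc1` gives > 100000 nM, again a limit of this assay.

Compound 1 therefore sits at the limit of > 100000 nM in this assay, at which 2 of the 3 values shown sit, so only a boundary, not a true position, is known for it. Compound 4 `O=C1O/C(=C\Cn2cc(-c3cccc(O)c3)nn2)C(OCc2ccccc2)=C1OCc1ccccc1` is the unmeasured partner; it differs from compound 1 by 3-hydroxyphenyl in place of 4-bromophenyl on an aromatic carbon. Among the measured compounds shown here, no measured pair shows what this change does. With only a limit to start from, the step of a number no higher from compound 1 to compound 4 (the limit leaves the size open) is expected to be none beyond the scatter, most likely ending at the limit again. Compound 4 is estimated at 100000 nM, with a range from 20000 nM to 300000 nM.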

Compound 4, half-maximal inhibitory concentration: 42600 nM
Estimate against measurement, compound 4: 2.3-fold (0.37 log units) above, and the stated range covers the measured number.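

In this assay, 3-hydroxyphenyl in place of 4-bromophenyl on this aromatic carbon gives an at least 2.3-fold lower number from compound 1 to compound 4 (0.37 log units; beyond the scatter), so the read-out does respond to a change at this position. Compound 4 has a true number, whereas compound 1 has only a limit, so the real size of the step stays unknown, and that limit is a common one here: the limit of > 100000 nM in this assay, at which 2 of the 4 values shown sit.

On these data alone, whether the step comes from the hydroxyl group, its place on the phenyl ring or the loss of bromine stays open. A 4-hydroxyphenyl or 3-aminophenyl group at the same position would help separate these.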